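Bromo in Place of Fluoro: What to Expect from Compound 3

This account rests on a few compounds, and the source may have more. Where it says the series, first, only, none or still open, it means among the compounds named here.

Compound 1, `COc1cc2c(Oc3ccc(NC(=O)c4nn(-c5ccccc5Br)c(=O)c5ccccc45)cc3F)ccnc2cc1OCCCN1CCCC1`: 320 nM
Compound 2, `COc1cc2c(Oc3ccc(NC(=O)c4nn(-c5ccccc5F)c(=O)c5ccccc45)cc3F)ccnc2cc1OCCCN1CCC(C)CC1`: 200 nM

Both compounds were tested in a functional assay on NCI-H460 cells (Homo sapiens) for cytotoxicity, read by MTT assay, with a stated time of 72 h; a higher number here means a weaker inhibitor, a lower number a stronger inhibitor. Compound 2 gives the lower of the two numbers shown, but its gap to compound 1 lies within the usual scatter of such measurements, so the two cannot be told apart on this evidence. Compound 1 and compound 2 also differ in more than one place, so no single structural change can be read from their pair.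

Compound 3, `COc1cc2c(Oc3ccc(NC(=O)c4nn(-c5ccccc5Br)c(=O)c5ccccc45)cc3F)ccnc2cc1OCCCN1CCC(C)CC1`, has not yet been measured in this assay. It is built from compound 2 by one change: bromo in place of fluoro on an aromatic carbon. Compound 1, which carries the same bromo group, gives 320 nM in this assay, a number within the scatter of compound 2. On that basis the step from compound 2 to compound 3 is expected to be no larger than the scatter, in either direction, a 1.3-fold higher number from compound 2 to compound 3 (0.10 log units; within the scatter). Compound 3 is therefore estimated at 250 nM in this assay, with a likely range from 120 nM to 520 nM.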

Compound 3, half-maximal inhibitory concentration: 390 nM
The estimate for compound 3 lay 1.6-fold (0.19 log units) below the measured number, within the range that was stated.
By their numbers in this assay, from the lowest: compounds 2, 1 and 3 (each within the scatter of the next).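

Within the data shown here, compound 3 gives the first readings of single changes. In this assay, 2-bromophenyl in place of 2-fluorophenyl, on an aromatic carbon ortho to a large group, gives a step that stays inside the usual scatter (a 2.0-fold higher number from compound 2 to compound 3 (0.29 log units; within the scatter)), so this position shows no measurable preference between these two halogens. The second single change lies at the far end of the chain, where 4-methylpiperidin-1-yl stands in place of pyrrolidin-1-yl, and this step also stays inside the scatter (a 1.2-fold higher number from compound 1 to compound 3 (0.09 log units; within the scatter)), so in this small set neither the halogen nor the ring on the chain separates the compounds in this cell assay. No measurement offered here accounts for either step.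

Among these compounds, whether the same position would stay this flat with a hydrogen, a methoxy group or a nitrile in place of the halogen remains open, since fluoro and bromo are the only groups seen there. At the chain end, an open-chain amine such as dimethylamino, or a morpholin-4-yl ring, could still show whether the amine matters to this cell-killing read-out.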